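Naphthalen-2-yl sulfonamide as successor to a bromophenyl sulfonamide

The source may hold more compounds than are shown below. What is called first, only, known or untested is meant among the compounds shown, and "the series" means these compounds.

Of the compounds shown here, two sharing one core have been tested in an assay on Sf9 cells for inhibition of mitogen-activated protein kinase kinase kinase 20 (Homo sapiens), read by ADP-Glo, with a stated time of 30 min; a higher number here means a weaker inhibitor, a lower number a stronger inhibitor. Compound 1 `COc1n[nH]c2ncc(-c3cn(-c4cc(NS(=O)(=O)c5cccc(Cl)c5)ccc4F)nn3)cc12` gives 5.7 nM. Compound 2 `COc1n[nH]c2ncc(-c3cn(-c4c(F)ccc(NS(=O)(=O)c5cccc(Br)c5)c4F)nn3)cc12` gives 2.1 nM, the lower of the two numbers, and its gap to compound 1 lies beyond the usual scatter, so compound 2 counts as the stronger inhibitor of the pair. Compound 3 `COc1n[nH]c2ncc(-c3cn(-c4c(F)ccc(NS(=O)(=O)c5ccc6ccccc6c5)c4F)nn3)cc12` is the next compound, not yet measured. Its difference from compound 2 is naphthalen-2-yl in place of 3-bromophenyl on a sulfonyl sulfur. For the measured compounds named here, no comparison between measured compounds speaks to this change, so the expectation rests on the two values alone. He expects compound 3 to stay near compound 2, with a step of a 1.9-fold higher number from compound 2 to compound 3 (0.28 log units; within the scatter) that may not rise beyond the scatter. His estimate for compound 3 in this assay is 4 nM, within a range from 1.5 nM to 12 nM.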

Compound 3, half-maximal inhibitory concentration: 4.5 nM
Beside the measured number, compound 3's estimate is 1.1-fold (0.05 log units) below it; the range from low to high includes it.
By their numbers in this assay, from the lowest: compound 2; then compounds 3 and 1 (each within the scatter of the next).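

In this assay, for the compounds shown here, naphthalen-2-yl in place of 3-bromophenyl on a sulfonyl sulfur gives the first direct reading at this position, with a 2.1-fold higher number from compound 2 to compound 3 (0.33 log units; beyond the scatter) as a modest loss that lies just beyond the scatter. Compound 3 carries no bromine and has two six-membered aromatic rings of carbon only, yet it still gives 4.5 nM in this assay. The position therefore accepts the larger naphthalen-2-yl group, and the bromine of compound 2 is not needed for a nanomolar value, though compound 2 keeps the lower number.

The compounds shown leave open whether this sulfonyl sulfur would also carry something other than an aromatic ring of carbon only, such as an amine, a carboxylic acid or a short alkyl chain. Nothing at hand accounts for the size of this step.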